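Lactam to cyclic urea on the chain carbon

This account rests on a few compounds, and the source may have more. Where it says the series, first, only, none or still open, it means among the compounds named here.

Measured compounds:
compound 1 `CCn1ncc2c(F)cc(-c3ccc(C(CC)(CC)c4nnc(C)[nH]4)c(=O)[nH]3)cc21` — > 3 h
compound 2 `CC(C)C(c1ccc(-c2ccc3cccc(F)c3c2)[nH]c1=O)N1CCCCC1=O` — 0.183 h

Among the compounds with values here, in an ADME assay on microsomes from liver (Homo sapiens) for metabolic stability (a higher number here means that the compound lasts longer, a lower number that the compound disappears faster), compound 2 gives 0.183 h, the only plain number in the set. For compound 1 the value > 3 h is a limit of the assay and not a number (the limit of > 3 h in this assay, at which 1 of the 2 values shown sits). Compound 3 `CC(C)C(c1ccc(-c2ccc3cccc(F)c3c2)[nH]c1=O)N1CCNC1=O` differs from compound 2 by 2-oxoimidazolidin-1-yl in place of 2-oxopiperidin-1-yl on a saturated chain carbon bound to an aromatic carbon and a saturated chain carbon. Within the data shown here, no step between measured compounds covers a change of this kind, so in this assay only a modest step toward a longer half-life is expected, close to the usual scatter. Compound 3 is expected to give 0.4 h (range 0.15 h to 1.2 h), an estimated step of a 2.2-fold higher number from compound 2 to compound 3 (0.34 log units; beyond the scatter).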

Compound 3, half-life: 1.03 h
The estimate for compound 3 lay 2.6-fold (0.41 log units) below the measured number, within the range that was stated.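

In this assay putting 2-oxoimidazolidin-1-yl in place of 2-oxopiperidin-1-yl on this saturated chain carbon gives a 5.6-fold higher number from compound 2 to compound 3 (0.75 log units; beyond the scatter) and so shows that half-life in this series responds to the ring at this position. The entering group has a five-membered ring and a hydrogen-bond donor, and this single pair cannot separate those two differences. Nothing at hand gives a cause for the step. Still open, going by these compounds, is how 2-oxopyrrolidin-1-yl, a five-membered ring without that donor, would compare in this assay with both groups. On these data alone, a methyl on the ring nitrogen of 2-oxoimidazolidin-1-yl is equally open.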